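The compounds below may be only part of what the source reports. "The series", "measured", "known", "first", "only" and "open" are said of these compounds alone.

Three compounds share one core and differ only in the groups hung on it. Compound 1 `Cc1cccc(C)c1NC(=O)/C=C/C(=O)N1C/C(=C\c2ccccc2)C(=O)/C(=C/c2ccccc2)C1` gives 22000 nM in a functional assay on L1210 cells (Mus musculus) for cytotoxicity (a higher number here means a weaker inhibitor, a lower number a stronger inhibitor), and compound 3 `Cc1ccc(NC(=O)/C=C/C(=O)N2C/C(=C\c3ccccc3)C(=O)/C(=C/c3ccccc3)C2)cc1C` gives 31000 nM; the step of a 1.4-fold higher number from compound 1 to compound 3 (0.15 log units; within the scatter) stays within the scatter. Compound 2 `CC(=O)c1ccc(NC(=O)/C=C/C(=O)N2C/C(=C\c3ccc([N+](=O)[O-])cc3)C(=O)/C(=C/c3ccc([N+](=O)[O-])cc3)C2)cc1` gives 1400 nM, the lowest of the three numbers, with gaps to compounds 1 and 3 that lie beyond the scatter. Compound 4 `Cc1cccc(C)c1NC(=O)/C=C/C(=O)N1C/C(=C\c2ccc([N+](=O)[O-])cc2)C(=O)/C(=C/c2ccc([N+](=O)[O-])cc2)C1` differs from compound 2 in one place: 2,6-dimethylphenyl in place of 4-acetylphenyl on an amide-type nitrogen. Going by the values given here, no measured step isolates this exchange; compounds 1 and 3 carry 2,6-dimethylphenyl or 3,4-dimethylphenyl but also differ from compound 2 elsewhere, so their higher numbers only hint that compound 4 may give a higher number. Compound 4 is therefore expected to give 5000 nM, within 1500 nM to 20000 nM. The expected step is a 3.6-fold higher number from compound 2 to compound 4 (0.55 log units; beyond the scatter).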

Compound 4, half-maximal inhibitory concentration: 690 nM
Compound 4: middle estimate off by 7.2-fold (0.86 log units), on the high side, and the stated range ends above it.
By their numbers in this assay, from the lowest: compound 4; then compound 2; then compounds 1 and 3 (each within the scatter of the next).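

In this assay, going by these compounds alone, putting 2,6-dimethylphenyl in place of 4-acetylphenyl on an amide-type nitrogen gives a 2.0-fold lower number from compound 2 to compound 4 (0.31 log units; beyond the scatter), a modest step but, unlike the one between compounds 1 and 3, beyond the scatter. The group on this nitrogen can therefore shift the number, and here the hydrogen-bond acceptor of 4-acetylphenyl leaves without the number rising. No available evidence gives a cause for this step. Open, from the compounds shown here alone, is whether a phenyl ring carrying a carboxylic acid or an amine on this nitrogen would shift the number further, and whether a longer chain would serve there at all.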